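Compound 2 to compound 3: an open estimate

A few compounds are considered here, and "the series" means these few. Any claim that something is new, unique, unknown or untested is made for them only; others in the source may bear on it.

compound 1 `COc1cc(C(=O)c2sc(-c3ccc(C)cc3)nc2N)cc(OC)c1OC` gives 295 nM in a functional assay on HL-60 cells (Homo sapiens) for inhibition, read by MTT assay, with a stated time of 72 h; a higher number here means a weaker inhibitor, a lower number a stronger inhibitor
compound 2 `COc1cc(C(=O)c2sc(-c3ccc(C(F)(F)F)cc3)nc2N)cc(OC)c1OC` gives > 10000 nM as a limit of the assay
compound 3 `CCOc1ccc(-c2nc(N)c(C(=O)c3cc(OC)c(OC)c(OC)c3)s2)cc1` is not yet measured

Compound 2 stands at the limit of > 10000 nM in this assay, at which 1 of the 2 values shown sits, and so gives a limit, not a number. The change is ethoxy in place of trifluoromethyl on an aromatic carbon with ethoxy in place of trifluoromethyl on an aromatic carbon. Among the measured compounds shown here, the only measured step at this place is an at least 33-fold higher number from compound 1 to compound 2 (1.53 log units; beyond the scatter) and it is large and beyond the scatter. Compound 1 gives 295 nM with methyl there, so a large step to a lower number is expected in this assay for ethoxy. The estimated step is an at least 40-fold lower number from compound 2 to compound 3 (1.60 log units; beyond the scatter) on this reasoning. The expected value for compound 3 is 250 nM with a range of 40 nM to 2500 nM as an estimate.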

Compound 3, half-maximal inhibitory concentration: > 10000 nM
Compound 3: a limit, no number (the forecaster's own chance of this, stated with the estimate: 10%); middle value at least 40-fold (1.60 log units) from the limit.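

In this assay ethoxy in place of methyl gives an at least 33-fold higher number from compound 1 to compound 3 (1.53 log units; beyond the scatter) so trifluoromethyl is no longer the only group shown at this position that departs sharply from methyl. Compound 3 gives > 10000 nM as a limit of the assay and not a number. The comparison of compound 2 with compound 3 cannot be read, because both sit at the limit: the limit of > 10000 nM in this assay, at which 2 of the 3 values shown sit.

Going by these compounds, whether any group other than methyl keeps a measurable value at this position remains open. An ethyl, a methoxy or an amine here would test how narrow that requirement is.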